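The compounds below may be only part of what the source reports. "The series", "measured", "known", "first", "only" and "open" are said of these compounds alone.

Among the measured compounds shown here, in an ADME assay on MT4 cells (Homo sapiens) for cytotoxicity, read by MTT assay (on this read-out lower numbers stand for higher toxicity in this test and higher numbers for lower toxicity in this test), two compounds with a shared core have numbers so far. Compound 1 (`O=C1c2ccccc2C(=O)N1CCOC(=S)N(C(=O)c1cccc(Cl)c1Cl)c1ccc(Cl)cc1`) gives 54000 nM and compound 2 (`O=C1c2ccccc2C(=O)N1CCOC(=S)N(C(=O)c1ccc(Cl)cc1Cl)c1ccc(Cl)cc1`) gives 18000 nM as the lower of the two, so compound 2 stands at the more toxic end of this small set. Compound 3 (`O=C1c2ccccc2C(=O)N1CCOC(=S)N(C(=O)c1cc([N+](=O)[O-])ccc1Cl)c1ccc(Cl)cc1`) keeps the core and alters only the acyl aryl group: 2-chloro-5-nitrophenyl in place of 2,4-dichlorophenyl on a carbonyl carbon. For the measured compounds named here, only one measured step bears on this place. That step (a 3.0-fold lower number from compound 1 to compound 2 (0.48 log units; beyond the scatter)) lies beyond the scatter but is modest, and it exchanges one dichlorophenyl group for another. Going by the values given here, no measured compound carries the 2-chloro-5-nitrophenyl group, so the data give no firm direction for it. A modest step is therefore the most that can be expected in this assay and none beyond the scatter is predicted, with a slight lean towards the higher number of compound 1 (54000 nM). The expected change is small (a 1.4-fold higher number from compound 2 to compound 3 (0.14 log units; within the scatter)) and stays within the scatter. For compound 3 the estimated value is 25000 nM with an expected range from 8000 nM to 70000 nM on this read-out.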

Compound 3, half-maximal cytotoxic concentration: 45000 nM
Compound 3: middle estimate off by 1.8-fold (0.26 log units), on the low side, and the stated range covers the measured number.
By their numbers in this assay, from the lowest: compound 2; then compounds 3 and 1 (each within the scatter of the next).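

In this assay the acyl aryl position now has a third group, and the exchange of 2,4-dichlorophenyl for 2-chloro-5-nitrophenyl gives a 2.5-fold higher number from compound 2 to compound 3 (0.40 log units; beyond the scatter) on a scale of modest size. The exchange of 2,3-dichlorophenyl for the same group gives a 1.2-fold lower number from compound 1 to compound 3 (0.08 log units; within the scatter) without leaving the scatter, so a ring carrying a nitro group in place of a second chlorine sits level with compound 1, and compound 2 alone stands apart as the most toxic of the three in this test. No measurement offered here explains why the 2,4-dichlorophenyl group differs from the other two.

All three acyl groups keep a chlorine at the 2 position of the ring, so the compounds leave open how an unsubstituted phenyl, or a ring carrying an amine or a carboxylic acid, would read in this assay on this carbonyl carbon. Going by these compounds, the 4-chlorophenyl group and the chain of the shared core are the same throughout, so what a change in either would do to these numbers also remains open.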